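Losing the Diethylamino Chain: From Compound 1 to Compound 4

This account rests on a few compounds, and the source may have more. Where it says the series, first, only, none or still open, it means among the compounds named here.

In a functional assay on HepG2 cells (Homo sapiens), read by MTT assay, with a stated time of 48 h (on this read-out higher numbers stand for weaker inhibition and lower numbers for stronger inhibition), compound 1 `CCN(CC)CCNC(=O)c1ccc(C(CC)(CC)c2ccc(OCC(O)C(C)(C)C)c(C)c2)n1CC` gives the lowest of three numbers, 490 nM. Compound 2 `CCN(CC)CCCNC(=O)c1ccc(C(CC)(CC)c2ccc(OCC(O)C(C)(C)C)c(C)c2)n1CC` gives 1100 nM, and compound 3 `CCn1c(C(=O)NCC(OC)OC)ccc1C(CC)(CC)c1ccc(OCC(O)C(C)(C)C)c(C)c1` gives 23200 nM. Compound 4 `C=CCN(C)C(=O)c1ccc(C(CC)(CC)c2ccc(OCC(O)C(C)(C)C)c(C)c2)n1CC` remains unmeasured and differs from compound 1 as follows: allyl(methyl)amino in place of (2-(diethylamino)ethyl)amino on a carbonyl carbon. Lengthening the chain gave only a modest step, a 2.2-fold higher number from compound 1 to compound 2 (0.35 log units; beyond the scatter). Replacing the diethylamino end with dimethoxymethyl gave a large one, a 47-fold higher number from compound 1 to compound 3 (1.68 log units; beyond the scatter), and a 21-fold higher number from compound 2 to compound 3 (1.32 log units; beyond the scatter) was also large. Compound 4 likewise has no diethylamino group, so a large step to a higher number is expected in this assay. The estimated step is a 31-fold higher number from compound 1 to compound 4 (1.49 log units; beyond the scatter). For compound 4 the expected value is 15000 nM, within an estimated range of 5000 nM to 40000 nM.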

Compound 4, half-maximal inhibitory concentration: > 50000 nM
Compound 4 ended at the assay's limit (the forecaster's own chance of this, stated with the estimate: 10%); middle value at least 3.3-fold (0.52 log units) from the limit.
By their numbers in this assay, from the lowest: compound 1; then compound 2; then compound 3. At a limit, above all of these: compound 4.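

In this assay compound 4 stands at a limit of the assay, so its steps are bounds and not exact sizes: the limit of > 50000 nM in this assay, at which 1 of the 4 values shown sits. At this carbonyl carbon, allyl(methyl)amino costs more than any chain change seen earlier, with an at least 100-fold higher number from compound 1 to compound 4 (2.00 log units; beyond the scatter) and an at least 45-fold higher number from compound 2 to compound 4 (1.65 log units; beyond the scatter). Even against the other amide without a diethylamino end there is an at least 2.1-fold higher number from compound 3 to compound 4 (0.33 log units; beyond the scatter), so removing that end does not mark the floor of activity here.

The compounds shown do not separate the allyl group from the methyl group on the amide nitrogen. A plain allylamino group, or a (2-(diethylamino)ethyl)(methyl)amino group, would address this.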